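A few compounds are considered here, and "the series" means these few. Any claim that something is new, unique, unknown or untested is made for them only; others in the source may bear on it.

Three compounds share one core. Compound 1 `O=[N+]([O-])c1ccc(-c2csc(N3N=C(c4ccc(N5CCCCC5)cc4)CC3c3ccc(Cl)cc3)n2)cc1` carries a nitro group on an aromatic carbon. In a functional assay on A-375 cells (Homo sapiens) for antiproliferative activity, read by MTT assay, with a stated time of 72 h (a lower number here means a stronger inhibitor, a higher number a weaker inhibitor), compound 1 reaches only a limit of the assay, > 100000 nM, which is a limit and not a measured number. Compound 2 `N#Cc1ccc(-c2csc(N3N=C(c4ccc(N5CCCCC5)cc4)CC3c3ccc(Cl)cc3)n2)cc1` has cyano in place of that nitro, and in this assay compound 2 gives 38700 nM. This change brings an at least 2.5-fold lower number from compound 1 to compound 2 (0.41 log units; beyond the scatter), a size known only as a lower bound because compound 1 sits at the limit of > 100000 nM in this assay, at which 1 of the 2 values shown sits. Compound 2 therefore holds the only actual number shown, while the other value is a limit.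

Compound 3 `Cc1ccc(-c2csc(N3N=C(c4ccc(N5CCCCC5)cc4)CC3c3ccc(Cl)cc3)n2)cc1` differs from compound 2 by methyl in place of cyano on an aromatic carbon. Among the compounds with values here, no measured step swaps cyano for methyl, so the single measured step, from nitro to cyano, does not bear directly on this change. The expectation for compound 3 in this assay is accordingly a step of no more than the scatter, a 1.0-fold higher number from compound 2 to compound 3 (0.01 log units; within the scatter), held with wide uncertainty. Compound 3 is estimated at 40000 nM, within a range from 12000 nM to 100000 nM.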

Compound 3, half-maximal inhibitory concentration: > 100000 nM
Compound 3: only a limit was reported; the forecaster's own chance of this, stated with the estimate: 25%; middle value at least 2.5-fold (0.39 log units) away from the limit.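

Methyl in place of cyano on the aromatic carbon para to a large group brings an at least 2.5-fold higher number from compound 2 to compound 3 (0.41 log units; beyond the scatter) in this assay, a size known only as a lower bound. The nitrile therefore cannot be swapped freely at this position: compound 2, at 38700 nM, is the only one of the three with a measured number, while both the nitro group and the methyl group leave the compound without one, so this single spot on the ring can decide whether any number is obtained at all. Compound 1 and compound 3 stop at one and the same limit, so the step between them cannot be read and the nitro and methyl groups cannot be ranked against each other: the limit of > 100000 nM in this assay, at which 2 of the 3 values shown sit.

With only one measured number, the compounds shown leave open whether the nitrile is unusual here or whether other groups could match it or bring the number lower. An amine, a carboxylic acid or a longer chain such as ethyl on this same carbon would show whether anything beyond the nitrile gives a measurable number in this assay.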